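A few compounds are considered here, and "the series" means these few. Any claim that something is new, unique, unknown or untested is made for them only; others in the source may bear on it.

Compound 1 `Oc1ccc(OC(=S)Nc2ccc(Sc3ccc(C(Cl)(Cl)Cl)cc3)cc2)cc1` gives 9.22
Compound 2 `CC(=O)Nc1ccc(OC(=S)Nc2ccc(Sc3ccc(C(Cl)(Cl)Cl)cc3)cc2)cc1` gives 9.01
Compound 3 `Oc1ccc(OC(=S)Nc2ccc(Nc3ccc(C(Cl)(Cl)Cl)cc3)cc2)cc1` gives 9.23

These three compounds were measured in a physicochemical assay for acid dissociation. Compound 1 and compound 2 share one core and differ in a single place: acetamido in place of hydroxy on an aromatic carbon. That change gave a number 0.21 log units lower from compound 1 to compound 2 (within the scatter). Compound 3 carries the same hydroxy group on another core; how the core of compound 3 differs from the core of compound 1 is not broken down here. The values of compound 1 and compound 3 lie within the scatter of each other, and so do those of compound 2 and compound 3.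

Compound 4 `CC(=O)Nc1ccc(OC(=S)Nc2ccc(Nc3ccc(C(Cl)(Cl)Cl)cc3)cc2)cc1` has not yet been measured. It differs from compound 3 in a single place: acetamido in place of hydroxy on an aromatic carbon. For the measured compounds named here, this is the same change as the one between compound 1 and compound 2, made at the same kind of position. A step of similar size is expected in this assay, a number 0.21 log units lower from compound 3 to compound 4 (within the scatter), because the same change earlier gave a number 0.21 log units lower from compound 1 to compound 2 (within the scatter). On that basis compound 4 is expected to give about 9.02, most likely between 8.7 and 9.35.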

Compound 4, acid dissociation constant: 9.01
Estimate against measurement, compound 4: 0.01 log units above; low and high end bracket the measured number.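

In this assay the swap of hydroxy for acetamido on the core of compound 3 gave a number 0.22 log units lower from compound 3 to compound 4 (within the scatter) and on the core of compound 1 it gave a number 0.21 log units lower from compound 1 to compound 2 (within the scatter) so the step read on one core carried over to the other with a similar size. This does not show that the swap truly moves the number, since both steps lie within the scatter, and two cores are too few to show a rule for the whole series. Nothing available here explains the result.

The compounds shown carry only hydroxy or acetamido at this place, so it remains open how an amine or a carboxylic acid there would read in this assay and whether either would give a step beyond the scatter. Also open, as far as these compounds go, are a longer chain in place of acetamido and whether the same step would hold on a core other than these two.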